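The source may report more compounds than this note shows. Statements on the series, on what has been measured and on what is new or still open speak of the compounds shown alone.

In a functional assay on OVCAR-3 cells (Homo sapiens) for antiproliferative activity, read by MTT assay, with a stated time of 24 h; on this read-out higher numbers stand for weaker inhibition and lower numbers for stronger inhibition:
Compound 1 `Cc1ccccc1NNC(=O)c1ccccc1NS(=O)(=O)c1cnc(O)nc1O`: > 20000 nM
Compound 2 `Cc1cccc(NNC(=O)c2ccccc2NS(=O)(=O)c2cnc(O)nc2O)c1`: > 20000 nM
Compound 3 `O=C(NNC(=O)c1ccccc1NS(=O)(=O)c1cnc(O)nc1O)c1cccc(Cl)c1`: 2080 nM

The entries for compound 1 and compound 2 are limits and not numbers, as shown by the limit of > 20000 nM in this assay, at which 2 of the 3 values shown sit. Compound 3 alone has a true number, 2080 nM, so it is the only measured reference point for what follows.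

Compound 4 `O=C(NNC(=O)c1ccccc1NS(=O)(=O)c1cnc(O)nc1O)c1ccccc1F` is the next to be read. It keeps the shared core and the carbonyl of compound 3 and differs in one group: 2-fluorophenyl in place of 3-chlorophenyl on a carbonyl carbon. The change sits on a carbonyl carbon whose other neighbour is an amide-type nitrogen.

Going by the values given here, two measured steps bear on it only indirectly: an at least 9.6-fold lower number from compound 1 to compound 3 (0.98 log units; beyond the scatter) and an at least 9.6-fold lower number from compound 2 to compound 3 (0.98 log units; beyond the scatter). Both lie beyond the scatter, and both bring in the (3-chlorophenyl)carbonyl group in place of a methylphenyl group on an amine nitrogen. Compound 4 retains a carbonyl there, so the gain seen in those steps is expected to be largely kept. Among the compounds with values here, the remaining step, a step that the two limits leave unreadable from compound 1 to compound 2, gives no size, and no measured step changes the ring on the carbonyl. The expected result is therefore no change beyond the scatter, with no firm direction: a 1.2-fold higher number from compound 3 to compound 4 (0.08 log units; within the scatter). Compound 4 is estimated at 2500 nM, with an expected range of 800 nM to 9000 nM.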

Compound 4, half-maximal inhibitory concentration: 15300 nM
Compound 4: the middle estimate sits 6.1-fold (0.79 log units) below what was measured, outside the stated range (above it).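

In this assay, the ring on a carbonyl carbon whose other neighbour is an amide-type nitrogen proves to matter for the read-out: 2-fluorophenyl in place of 3-chlorophenyl gives a 7.4-fold higher number from compound 3 to compound 4 (0.87 log units; beyond the scatter). The earlier compounds shown here showed a gain beyond the scatter for (3-chlorophenyl)carbonyl in place of either methylphenyl group, but the carbonyl alone does not secure that gain, as (2-fluorophenyl)carbonyl gives an at least 1.3-fold lower number from compound 2 to compound 4 (0.11 log units; that floor lies within the scatter) and an at least 1.3-fold lower number from compound 1 to compound 4 (0.11 log units; that floor lies within the scatter), and both of these floors lie within the scatter. These two steps can be read only as floors because compound 1 and compound 2 are known only through a limit: the limit of > 20000 nM in this assay, at which 2 of the 4 values shown sit.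

The halogen and its place on the ring change together in the step to compound 4, so the compounds shown do not separate the effect of one from the other. Going by these compounds, how an amine or a carboxylic acid on that ring, or a longer chain in place of the ring, would read in this assay also stays open.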